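Capping a Hydroxy Group on the Most Polar Compound

The source may hold more compounds than are shown below. What is called first, only, known or untested is meant among the compounds shown, and "the series" means these compounds.

In a physicochemical assay for lipophilicity (a lower number here means a more polar compound, a higher number a more lipophilic compound), compound 3 `O=C(O)[C@H]1CSC(c2cc(O)ccc2O)=N1` gives -1.52, the lowest of the three numbers available. Compound 2 `C[C@]1(C(=O)O)CSC(c2cc(O)ccc2O)=N1` stands higher at -1.14, and compound 1 `COc1ccc(C2=N[C@@H](C(=O)O)CS2)c(O)c1` stands higher still at -0.89. Both gaps from compound 3 lie beyond the scatter.

The next compound to be measured is compound 4 `COc1ccc(O)c(C2=N[C@@H](C(=O)O)CS2)c1`. It departs from compound 3 through methyl in place of hydrogen on an oxygen on an aromatic ring, hydroxy to methoxy: methyl in place of hydrogen on an oxygen on an aromatic ring.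

Among the compounds with values here, no two measured compounds differ in one place only, so this series offers no direct precedent for the size of the step. The closest guide is compound 1, which also carries a methoxy group and reads -0.89 in this assay. On that value, a rise beyond the scatter is expected, of moderate size. The estimated change is a number 0.57 log units higher from compound 3 to compound 4 (beyond the scatter). Compound 4 is expected to read -0.95, within an estimated range from -1.3 to -0.6.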

Compound 4, partition coefficient: -0.81
Estimate against measurement, compound 4: 0.14 log units below; the range from low to high includes it.
By their numbers in this assay, from the lowest: compound 3; then compounds 2, 1 and 4 (each within the scatter of the next, the first and the last beyond it).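

Within the data shown here, compound 3 and compound 4 are the first pair that differ in one place only, so the size of this change can now be read directly. In this assay, methyl in place of hydrogen on an oxygen on an aromatic ring gives a number 0.71 log units higher from compound 3 to compound 4 (beyond the scatter), a modest step but one that lies beyond the scatter. Nothing measured here accounts for the step.

From the compounds shown here alone, whether an ethyl group or a longer chain on this oxygen would carry the number further, and what an amine in place of the hydroxy would do, remains open. Among these compounds, only this one pair shows the change, so it is also open whether hydroxy to methoxy would give a similar step on another compound.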